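Hydroxy for chloro in a paw edema series

The source may hold more compounds than are shown below. What is called first, only, known or untested is meant among the compounds shown, and "the series" means these compounds.

Measured so far in a functional assay on the whole organism (strain albino) for inhibition, with Rattus norvegicus as the target, read by paw edema, with stated times of 1 h and 2 h, at a dose of 100 mg/kg by the oral route; a higher number here means more inhibition at the dose given (going by the name of the read-out), a lower number less inhibition:
compound 1, `N#Cc1c(-c2ccc(Cl)cc2)nc(SCC(=O)Nn2c(COc3ccc(Cl)cc3Cl)nc3ccccc3c2=O)n(Cc2ccccc2)c1=O`: 77.2%
compound 2, `N#Cc1c(-c2ccc(O)cc2)nc(SCC(=O)Nn2c(COc3ccc(Cl)cc3Cl)nc3ccccc3c2=O)n(Cc2ccccc2)c1=O`: 56.1%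
compound 3, `N#Cc1c(Cl)nc(SCC(=O)Nn2c(COc3ccc(Cl)cc3Cl)nc3ccccc3c2=O)nc1-c1ccc(Cl)cc1`: 68.4%

Compound 1 and compound 2 share one core and differ only by hydroxy in place of chloro on an aromatic carbon. That change gives a number 21.1 percentage points lower from compound 1 to compound 2 (beyond the scatter). Compound 3 sits on a different core; how its core differs from that of compound 1 is not broken down here. Compound 3 stands within the scatter of compound 1 in this assay, and beyond the scatter above compound 2.

Compound 4, `N#Cc1c(Cl)nc(SCC(=O)Nn2c(COc3ccc(Cl)cc3Cl)nc3ccccc3c2=O)nc1-c1ccc(O)cc1`, is not yet measured. It relates to compound 3 by hydroxy in place of chloro on an aromatic carbon, which is the same change as that from compound 1 to compound 2, at the same kind of place, para to a large group. Compound 4 is expected to lose ground against compound 3 by about a number 20.4 percentage points lower from compound 3 to compound 4 (beyond the scatter), because the same change gave a number 21.1 percentage points lower from compound 1 to compound 2 (beyond the scatter) on the other core. Within the data shown here, only one pair supports this, so the range is kept wide. Compound 4 is estimated at 48% in this assay, within 34% to 62%.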

Compound 4, a percentage reported as inhibition, in the whole organism at one dose (the size of the read-out at that dose, not a potency): 73.7%
Estimate against measurement, compound 4: 25.7 percentage points below, outside the stated range (above it).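

In this assay, hydroxy in place of chloro on an aromatic carbon gives a number 5.3 percentage points higher from compound 3 to compound 4 (within the scatter), so the clear loss seen on the core of compound 1 does not reappear on the core of compound 3. The two cores part on this change: the same change on two cores in this assay, a number 21.1 percentage points lower (beyond the scatter) from compound 1 to compound 2 and a number 5.3 percentage points higher (within the scatter) from compound 3 to compound 4, 26.4 percentage points apart, beyond the scatter of two such steps The step from 4-chlorophenyl to 4-hydroxyphenyl therefore does not carry over as a fixed amount between these two cores, but with one pair per core this neither explains the difference, nor shows a gain from hydroxy on the core of compound 3, nor gives a rule for any other core.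

The compounds shown leave open how an amine or a carboxylic acid in the same place would behave on either core. They also leave open whether the two cores part in the same way for changes other than this one.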